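The compounds below may be only part of what the source reports. "The series", "measured", "known", "first", "only" and "open" are said of these compounds alone.

Compound 1 `Cc1nc2c(/C=C/c3ccccc3)cccn2c1C` and compound 2 `Cc1nc2c(/C=C/c3ccccc3)cccn2c1N` share one core, while compound 3 `Cc1nc2c(C/C=C\c3ccccc3)cccn2c1C` and compound 4 `Cc1nc2c(C/C=C\c3ccccc3)cccn2c1N` share another; the difference between the two cores is not broken down here. In a functional assay on the whole organism (stomach) for inhibition, with Canis familiaris (Canis lupus familiaris) as the target, at a dose of 8 mg/kg by the oral route (a lower number here means a weaker effect, a higher number a stronger effect of the compound at the dose given), compound 1 gives 3% and compound 2 gives 6%, so the change amino in place of methyl on an aromatic carbon made a step of a number 3 percentage points higher from compound 1 to compound 2 (within the scatter). Compound 3 gives 0% in this assay, the lowest of the three numbers, though its gaps to compound 1 and compound 2 both lie within the scatter. Compound 4 carries the same change, (amino in place of methyl on an aromatic carbon), on the second core. Because the earlier step of a number 3 percentage points higher from compound 1 to compound 2 (within the scatter) stayed within the scatter, the step from compound 3 to compound 4 is expected to be similarly small, about a number 3 percentage points higher from compound 3 to compound 4 (within the scatter). Compound 4 is therefore estimated at 3%, between 0% and 12%, in this assay.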

Compound 4, a percentage reported as inhibition, in the whole organism at one dose (the size of the read-out at that dose, not a potency): 0%
Compound 4: the middle estimate sits 3 percentage points above what was measured, within the range that was stated.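

In this assay, amino in place of methyl on an aromatic carbon of the second core gave no change at the digits printed from compound 3 to compound 4 (within the scatter). The change carried from one core to the other with no difference that can be told from the scatter: the same change on two cores in this assay, a number 3 percentage points higher (within the scatter) from compound 1 to compound 2 and no change at the digits printed (within the scatter) from compound 3 to compound 4, 3 percentage points apart, within the scatter of two such steps. Going by these compounds alone, neither step can be told from the scatter, so the two pairs show only that this change had no readable effect on either core at this one dose; they do not show how it would behave on another core or at another dose.

The compounds shown leave open what other groups on that aromatic carbon would give in this assay. A hydroxyl group, a dimethylamino group or a longer chain such as ethyl or propyl are not among them.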